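A Methyl on an Aromatic Oxygen in Two Cores

The source may hold more compounds than are shown below. What is called first, only, known or untested is meant among the compounds shown, and "the series" means these compounds.

Of the compounds shown here, three have been measured in a functional assay on HeLa cells (Homo sapiens) for cytotoxicity, read by XTT assay, with a stated time of 72 h; a lower number here means a stronger inhibitor, a higher number a weaker inhibitor. Compound 1 `C=C1CC[C@H]2C(C)(C)CCC[C@]2(C)[C@H]1CC/C(C)=C/COc1cc(O)c2c(=O)c(O)c(-c3ccc(OC)cc3)oc2c1` gives only a limit of the assay, > 100000 nM. Compound 3 `C=C1CC[C@H]2C(C)(C)CCC[C@]2(C)[C@H]1CC/C(C)=C/COc1cc(O)c2c(=O)c(O)c(-c3ccc(O)cc3)oc2c1` likewise gives only a limit, > 100000 nM. Compound 2 `C=C1CC[C@H]2C(C)(C)CCC[C@]2(C)[C@H]1CC/C(C)=C/COc1c(-c2ccc(O)cc2)oc2cc(O)cc(O)c2c1=O` gives a number, 27000 nM. Compound 1 differs from compound 3 by methyl in place of hydrogen on an oxygen on an aromatic ring; the step that the two limits leave unreadable from compound 3 to compound 1 cannot be read because of the limit of > 100000 nM in this assay, at which 2 of the 3 values shown sit. Compound 2 and compound 3 have the same atoms joined differently; the difference between the two cores is not broken down here. Compound 4 `C=C1CC[C@H]2C(C)(C)CCC[C@]2(C)[C@H]1CC/C(C)=C/COc1c(-c2ccc(OC)cc2)oc2cc(O)cc(O)c2c1=O` is not yet measured. It differs from compound 2 by methyl in place of hydrogen on an oxygen on an aromatic ring, the same change as from compound 3 to compound 1, at the same place. With the measured instance a step that the two limits leave unreadable from compound 3 to compound 1 unreadable, the step of a 1.5-fold higher number from compound 2 to compound 4 (0.17 log units; within the scatter) is expected to be small. Compound 4 is therefore estimated at 40000 nM, between 12000 nM and 100000 nM.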

Compound 4, half-maximal inhibitory concentration: 30000 nM
Compound 4: middle estimate off by 1.3-fold (0.12 log units), on the high side; low and high end bracket the measured number.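

In this assay, the change from 4-hydroxyphenyl to 4-methoxyphenyl gives a 1.1-fold higher number from compound 2 to compound 4 (0.05 log units; within the scatter), so the two compounds cannot be told apart in this core. The matching step from compound 3 to compound 1 cannot be read, because both of its compounds sit at a limit of the assay rather than at a number: the limit of > 100000 nM in this assay, at which 2 of the 4 values shown sit.

The result therefore gives one readable instance of the change and does not show that the change behaves alike in both cores. The compounds shown leave open how a longer chain such as ethyl, or a group such as a carboxylic acid or an amine, would fare on that oxygen. They also leave open whether any change at this place would give a readable number in the core of compound 3.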